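Ethyl on an Amide Nitrogen in Two Core Settings

A few compounds are considered here, and "the series" means these few. Any claim that something is new, unique, unknown or untested is made for them only; others in the source may bear on it.

Measured compounds in an assay on membranes from HeLa cells for displacement of a labelled ligand from adenosine receptor A3 (Homo sapiens), read by scintillation counting, with a stated time of 180 min, tested at 1 uM; a higher number here means more inhibition at the concentration tested (going by the name of the read-out), a lower number less inhibition:
compound 1, `CCNC(=O)C1=C(C)NC(=O)NC1c1ccoc1`, gives 1%;
compound 2, `CCN(CC)C(=O)C1=C(C)NC(=O)NC1c1ccoc1`, gives 37%;
compound 3, `CC1=C(C(N)=O)C(c2ccsc2)NC(=O)N1`, gives 1%.

Compound 1 and compound 2 share a core and differ by ethyl in place of hydrogen on an amide-type nitrogen. That change brought a number 36 percentage points higher from compound 1 to compound 2 (beyond the scatter). Compound 3 stands level with compound 1, and how the core of compound 3 differs from the core of compound 1 is not broken down here. Compound 4, `CCNC(=O)C1=C(C)NC(=O)NC1c1ccsc1`, not yet measured, differs from compound 3 by ethyl in place of hydrogen on an amide-type nitrogen. This is the same kind of change as before, not the same: in the first case the amide-type nitrogen also bears a saturated chain carbon, in the second it bears only the carbonyl carbon. Compound 1 also carries an ethylcarbamoyl group and gives 1%. On that basis only a small step is expected for compound 4: a number 3 percentage points higher from compound 3 to compound 4 (within the scatter). Compound 4 is estimated at 4%, between 0% and 20%.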

Compound 4, a percentage reported as inhibition, at one concentration (the size of the read-out at that concentration, not a potency): 1%
Compound 4: middle estimate off by 3 percentage points, on the high side; the measured number falls inside the stated range.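

In this assay, ethyl in place of hydrogen on an amide-type nitrogen did not behave alike in the two settings: the same change on two cores in this assay, a number 36 percentage points higher (beyond the scatter) from compound 1 to compound 2 and no change at the digits printed (within the scatter) from compound 3 to compound 4, 36 percentage points apart, beyond the scatter of two such steps. The new step reads no change at the digits printed from compound 3 to compound 4 (within the scatter), and thiophen-3-yl in place of furan-3-yl on a saturated ring carbon reads no change at the digits printed from compound 1 to compound 4 (within the scatter), so at these low numbers the ring swap alone shows no effect. This does not show why the two ethyl steps differ, since the nitrogen also bears a saturated chain carbon in compound 1 but only the carbonyl carbon in compound 3.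

From the compounds shown here alone, whether a second ethyl on the nitrogen of compound 4 would raise the number as in compound 2 stays open. So does the effect of a longer chain, such as propyl, on that nitrogen.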